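Oxime ether chain: cyclopentyl to 3-hydroxypropyl

The source may hold more compounds than are shown below. What is called first, only, known or untested is meant among the compounds shown, and "the series" means these compounds.

Compound 3 `Nc1ncnc(Oc2ccc(NC(=O)C3(C(=O)Nc4ccc(F)cc4)CC3)cc2F)c1/C=N/OC1CCCC1` gives 4.27 in a physicochemical assay for lipophilicity, using the shake flask method (a lower number here means a more polar compound, a higher number a more lipophilic compound), the second highest of the three numbers: compound 2 `Nc1ncnc(Oc2ccc(NC(=O)C3(C(=O)Nc4ccc(F)cc4)CC3)cc2F)c1/C=N/OC1CCCCC1` gives 4.69 and compound 1 `C=CCO/N=C/c1c(N)ncnc1Oc1ccc(NC(=O)C2(C(=O)Nc3ccc(F)cc3)CC2)cc1F` gives 3.65. Compound 4 `Nc1ncnc(Oc2ccc(NC(=O)C3(C(=O)Nc4ccc(F)cc4)CC3)cc2F)c1/C=N/OCCCO` differs from compound 3 by 3-hydroxypropyl in place of cyclopentyl on an oxygen. The relevant step runs the other way: a number 0.62 log units higher from compound 1 to compound 3 (beyond the scatter), where cyclopentyl replaced a three-carbon allyl chain. Going back to a three-carbon chain should undo that, and the entering group also brings one hydrogen-bond donor and one acceptor that allyl lacked, so a drop larger than the reverse of that step is expected in this assay. Compound 4 is therefore estimated at 2.6, range 2 to 3.2, a step of a number 1.67 log units lower from compound 3 to compound 4 (beyond the scatter).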

Compound 4, partition coefficient: 2.67
The estimate for compound 4 lay 0.07 log units below the measured number; low and high end bracket the measured number.
By their numbers in this assay, from the lowest: compound 4; then compound 1; then compound 3; then compound 2.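

For the compounds shown here, compound 4 is the first here with a hydrogen-bond donor on this oxygen, and it sits lowest of the four in this assay, with a number 1.60 log units lower from compound 3 to compound 4 (beyond the scatter) and a number 2.02 log units lower from compound 2 to compound 4 (beyond the scatter). The comparison with the open-chain allyl group shows that removing a ring is not needed for a clear drop: a number 0.98 log units lower from compound 1 to compound 4 (beyond the scatter). At this position, 3-hydroxypropyl therefore lies below all three hydrocarbon groups.

No evidence on the origin of these steps is available. From the compounds shown here alone, how a 3-methoxypropyl chain, a longer hydroxyalkyl chain, an amine or a carboxylic acid would read on this oxygen remains open.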